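The source may hold more compounds than are shown below. What is called first, only, known or untested is meant among the compounds shown, and "the series" means these compounds.

Measured compounds in an assay on isolated protein (Cricetulus griseus) for binding affinity to Alpha-1B adrenergic receptor (Mesocricetus auratus), read by radioligand binding; a lower number here means a stronger inhibitor, a higher number a weaker inhibitor:
compound 1, `Oc1cccc2c1CCCC2c1c[nH]cn1`, gives 145 nM.
compound 2, `CCCS(=O)(=O)Nc1cccc2c1CCCC2c1c[nH]cn1`, gives only a limit, < 10000 nM.
compound 3, `O=S(=O)(Nc1cccc2c1CCCC2c1c[nH]cn1)C1CC1`, gives only a limit, < 10000 nM.

Compound 3 therefore stands not at a number but at a limit of this assay, the same limit at which compound 2 sits, as the limit of < 10000 nM in this assay, at which 2 of the 3 values shown sit, records. Compound 4, `CCS(=O)(=O)Nc1cccc2c1CCCC2c1c[nH]cn1`, differs from compound 3 by ethyl in place of cyclopropyl on a sulfonyl sulfur. The step that bears most closely on this change is a step that the two limits leave unreadable from compound 2 to compound 3, and a step that the limit leaves unreadable from compound 1 to compound 3 also touches it; neither can be read in size because both end at a limit. With no readable step of the same kind, no direction beyond the scatter can be expected, and compound 4 is estimated to remain near compound 3, a step that the limit leaves unreadable from compound 3 to compound 4. The estimate for compound 4 is 5000 nM, within 1000 nM to 10000 nM.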

Compound 4, inhibition constant: 1320 nM
Estimate against measurement, compound 4: 3.8-fold (0.58 log units) above, within the range that was stated.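

In this assay, (ethylsulfonyl)amino in place of hydroxy on the aromatic carbon gives a 9.1-fold higher number from compound 1 to compound 4 (0.96 log units; beyond the scatter), so this exchange now has a readable size and the higher number means weaker binding for compound 4. The steps that involve compound 2 or compound 3 still cannot be read, which leaves the ethyl, propyl and cyclopropyl groups on the sulfonyl sulfur unranked: the limit of < 10000 nM in this assay, at which 2 of the 4 values shown sit.

Open, going by these compounds, is how methyl or phenyl on the sulfonyl sulfur would compare with the ethyl of compound 4. Also open, on these data alone, is whether an amide in place of the sulfonamide would bring the number closer to that of compound 1.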